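A Chloro Step Repeated on a Second Core

The source may report more compounds than this note shows. Statements on the series, on what has been measured and on what is new or still open speak of the compounds shown alone.

Measured compounds:
compound 1 `COc1ccccc1S(=O)(=O)/C=C/c1ccccn1`: 100%
compound 2 `COc1ccccc1S(=O)(=O)/C=C/c1ccc(Cl)cn1`: 92.6%
compound 3 `COc1cccc(S(=O)(=O)/C=C/c2ccccn2)c1`: 98.9%

In an ADME assay on BV-2 cells (Mus musculus) for cytotoxicity, with a stated time of 24 h, tested at 50 uM (a higher number here means a weaker effect of the compound at the concentration tested, a lower number a stronger effect), compound 1 gives 100%. Compound 2 differs from compound 1 by chloro in place of hydrogen on an aromatic carbon, and in this assay compound 2 gives 92.6%. That step was a number 7.4 percentage points lower from compound 1 to compound 2 (within the scatter). Compound 3 has the same atoms as compound 1 joined differently; the difference between the two cores is not broken down here. In this assay compound 3 gives 98.9%, a number within the scatter of compound 1.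

Compound 4 `COc1cccc(S(=O)(=O)/C=C/c2cccc(Cl)n2)c1` has not yet been measured. It differs from compound 3 by chloro in place of hydrogen on an aromatic carbon. Within the data shown here, this is the same kind of change as the one from compound 1 to compound 2, but the surroundings differ: in compound 2 the chloro sits two atoms from the ring nitrogen and para to a large group, while in compound 4 it sits next to the ring nitrogen and meta to a large group. Among the measured compounds shown here, the only guide is the one measured step, which stayed within the scatter. A step of similar size is expected from compound 3 to compound 4, resting on a number 7.4 percentage points lower from compound 1 to compound 2 (within the scatter), with extra uncertainty because the place is not the same. Compound 4 is therefore expected to give 93% in this assay, between 78% and 100%. This estimate means a step of a number 5.9 percentage points lower from compound 3 to compound 4 (within the scatter).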

Compound 4, a percentage reported as activity, at one concentration (the size of the read-out at that concentration, not a potency): 89.3%
For compound 4 the middle estimate is 3.7 percentage points above the measured one; the range from low to high includes it.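

In this assay, the swap of hydrogen for chloro on an aromatic carbon of the second core gave a number 9.6 percentage points lower from compound 3 to compound 4 (within the scatter). Set beside the earlier step, the swap carries from one core to the other with no difference that can be told apart in this assay: the same change on two cores in this assay, a number 7.4 percentage points lower (within the scatter) from compound 1 to compound 2 and a number 9.6 percentage points lower (within the scatter) from compound 3 to compound 4, 2.2 percentage points apart, within the scatter of two such steps. This does not show that chloro has a real effect on the read-out, as each step on its own stays within the scatter, and it rests on just two pairs of compounds, with the chloro in a different place on the pyridine-type ring in each pair, so the core and the place cannot be separated, and agreement between the two steps says little about any further core.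

The compounds shown leave open whether another group put in place of that hydrogen, such as fluoro, methyl, an amine or a carboxylic acid, would follow the same course as chloro on these two cores. Also open, going by these compounds, is whether chloro in one and the same place on both cores would give matching steps, and whether a read-out taken at a single concentration would look the same at other concentrations.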